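The source may hold more compounds than are shown below. What is called first, only, known or untested is meant among the compounds shown, and "the series" means these compounds.

In a functional assay (aorta) with Rattus norvegicus as the target (on this read-out higher numbers stand for an effect only at larger amounts of compound and lower numbers for an effect already at smaller amounts), compound 1 `C[C@H](NC1=NS(=O)(=O)c2cccnc2N1)C1CCCCC1` gives 29.2 uM and compound 2 `C[C@H](NC1=NS(=O)(=O)c2cc(Cl)cnc2N1)C1CCCCC1` gives 3.8 uM as the lower of the two numbers. Compound 3 `C[C@H](NC1=NS(=O)(=O)c2cc(Cl)cnc2N1)c1ccccc1` keeps the chloro of compound 2 but carries phenyl in place of cyclohexyl on a saturated chain carbon bound to an amine nitrogen and a saturated chain carbon on that same saturated chain carbon. Among the compounds with values here, the only measured step, chloro in place of hydrogen on an aromatic carbon, is a 7.7-fold lower number from compound 1 to compound 2 (0.89 log units; beyond the scatter) and sits at a different place, so it sets no size for this swap. Only a small move to a higher number is expected, and it may stay within the scatter. The estimated step is a 1.6-fold higher number from compound 2 to compound 3 (0.20 log units; within the scatter) on this reasoning. For compound 3 the expected value is 6 uM with an estimated range of 1.5 uM to 22 uM around it.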

Compound 3, concentration for half-maximal effect: 21.2 uM
For compound 3 the middle estimate is 3.5-fold (0.55 log units) below the measured one, within the range that was stated.
By their numbers in this assay, from the lowest: compound 2; then compounds 3 and 1 (each within the scatter of the next).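

In this assay, the group on the saturated chain carbon bound to an amine nitrogen clearly counts: phenyl in place of cyclohexyl gives a 5.6-fold higher number from compound 2 to compound 3 (0.75 log units; beyond the scatter). Both groups are six-membered rings of carbon with the same count of heavy atoms, yet this change alone moves the number beyond the scatter. Nothing available explains this step.

Within the data shown here, the swap has been seen only with the chloro present, so its size without the chloro stays open. Also open, going by these compounds, is how an open-chain group such as isopropyl or a longer chain would behave at this place.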